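A few compounds are considered here, and "the series" means these few. Any claim that something is new, unique, unknown or untested is made for them only; others in the source may bear on it.

Compound 1 `C/C=C/C=C/C(=O)N1CCCCO1` | 0.75
Compound 2 `C/C=C/C=C/C(=O)OC(C)(C)C` | 2.33

In a physicochemical assay for lipophilicity (a higher number here means a more lipophilic compound, a lower number a more polar compound), compound 2 stands the higher of the two, and the gap between the two compounds lies beyond the scatter. Compound 1 gives 0.75 and compound 2 gives 2.33. Compound 3 `C=CCOC(=O)/C=C/C=C/C` has not yet been measured. It differs from compound 2 by allyl in place of tert-butyl on an oxygen next to a carbonyl group, with allyl in place of tert-butyl on an oxygen next to a carbonyl group. Within the data shown here, no measured pair shows this change, so the expectation is tentative. A modest fall is expected in this assay, a little beyond the scatter, with the estimated step of a number 0.43 log units lower from compound 2 to compound 3 (beyond the scatter). The estimate for compound 3 is 1.9, with an expected range of 1.55 to 2.25.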

Compound 3, partition coefficient: 2.24
Compound 3: middle estimate off by 0.34 log units, on the low side, within the range that was stated.
By their numbers in this assay, from the lowest: compound 1; then compounds 3 and 2 (each within the scatter of the next).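

In this assay, among these compounds, allyl in place of tert-butyl on an oxygen next to a carbonyl group gives a number 0.09 log units lower from compound 2 to compound 3 (within the scatter), the first step here between compounds that differ in one place. At this position, a group of 3 heavy atoms with a double bond outside aromatic rings therefore leaves the reading within the scatter of the group of 4 heavy atoms it replaces. Nothing available here bears on why the two readings stay so close. On these data alone, whether a benzyl group or a longer chain on the same oxygen would also stay within the scatter of compound 2 remains open. So does whether allyl in place of tert-butyl would give a similar step on another core.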